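Acetyl in Place of Bromo: What to Expect for Compound 4

A few compounds are considered here, and "the series" means these few. Any claim that something is new, unique, unknown or untested is made for them only; others in the source may bear on it.

Measured so far in a functional assay on the whole organism for inhibition, with Rattus norvegicus as the target; on this read-out higher numbers stand for an effect only at larger amounts of compound and lower numbers for an effect already at smaller amounts:
Compound 1, `CC1CC/C(=N\Nc2ccccc2Br)c2ncc(C(=O)O)c(=O)n21`, gives > 320 umol/kg, a limit of the assay.
Compound 2, `CC1CC/C(=N\Nc2cccc(Br)c2)c2ncc(C(=O)O)c(=O)n21`, gives > 320 umol/kg, a limit of the assay.
Compound 3, `COc1ccc(N/N=C2\CCC(C)n3c2ncc(C(=O)O)c3=O)cc1`, gives 7.6 umol/kg.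

Compound 2 therefore stands at the assay's limit, where most of the set sits (the limit of > 320 umol/kg in this assay, at which 2 of the 3 values shown sit). Compound 4, `CC(=O)c1cccc(N/N=C2\CCC(C)n3c2ncc(C(=O)O)c3=O)c1`, differs from compound 2 by acetyl in place of bromo on an aromatic carbon. Among the measured steps, a step that the two limits leave unreadable from compound 1 to compound 2, while an at least 42-fold lower number from compound 2 to compound 3 (1.62 log units; beyond the scatter); that last step replaces the whole bromophenyl with 4-methoxyphenyl, a change unlike the one leading to compound 4. For the measured compounds named here, no measured step exchanges a bromo for an acetyl, so the expectation rests on little. Compound 4 is expected to show an at least 2.1-fold lower number from compound 2 to compound 4 (0.32 log units; beyond the scatter), a movement that could well stay within the scatter. The estimate for compound 4 in this assay is 150 umol/kg, ranging from 25 umol/kg to 900 umol/kg.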

Compound 4, dose for 50% inhibition: > 1000 umol/kg
Compound 4 was reported as a limit; the forecaster's own chance of this, stated with the estimate: 40%; middle value at least 6.6-fold (0.82 log units) away from the limit.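

In this assay compound 2 and compound 4 both give limits rather than numbers, and the step between them cannot be read. The compounds shown leave open whether acetyl in place of bromo changes the dose needed at all.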